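Cyclohexyl in place of 1-phenylethyl on an acylguanidine amide nitrogen

The source may hold more compounds than are shown below. What is called first, only, known or untested is meant among the compounds shown, and "the series" means these compounds.

Measured compounds:
compound 1 `Cc1nc(N)sc1CCCN/C(N)=N/C(=O)N[C@H](C)c1ccccc1` — "not determined" (no result reported)
compound 2 `Cc1nc(N)sc1CCCN/C(N)=N/C(=O)NCC(C)CC1CCCCC1` — 0.6

In a functional assay on membranes from Sf9 cells for agonist activity at histamine H2 receptor (Homo sapiens), read by scintillation counting and GTPgammaS binding, with a stated time of 90 min (on this read-out lower numbers stand for smaller maximal responses and higher numbers for larger maximal responses), compound 1 gives "not determined" (no result reported), so no number places compound 1 on this read-out. In this assay compound 2 gives 0.6, which is the only numerical result here, and compound 2 shares the core of compound 1 while carrying a different group on the amide-type nitrogen. Compound 3 `Cc1nc(N)sc1CCCN/C(N)=N/C(=O)NC1CCCCC1` has not been measured. Its relation to compound 1 is cyclohexyl in place of 1-phenylethyl on an amide-type nitrogen. For the measured compounds named here, with no value for compound 1 and no step between two measured compounds, the size and direction of the change from compound 1 to compound 3 in this assay cannot be judged from the data; the only anchor is compound 2 with 0.6. The maximal response of compound 3 in this assay is estimated at 0.65, expected to fall between 0.45 and 0.85.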

Compound 3, intrinsic activity: the largest response reached, as a fraction of the reference agonist's: 0.96
The estimate for compound 3 lay 0.31 below the measured number; the measured number lies above the stated range.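

For the compounds shown here, compound 3 gives 0.96 in this assay but compound 1 has no number there, so no step between compound 1 and compound 3 can be read. Going by these compounds, what cyclohexyl in place of 1-phenylethyl does to the maximal response stays open. No evidence offered here bears on this result.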